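The compounds below may be only part of what the source reports. "The series", "measured", "known", "first", "only" and "open" are said of these compounds alone.

Compounds measured so far:
compound 1 `COc1ccc(-c2noc(C3CCCN3)n2)cc1OC1CCCC1` gives 43 nM
compound 2 `Fc1ccc(-c2nc(-c3ccccc3)no2)cc1` gives 23700 nM

In a functional assay on LNCaP cells (Homo sapiens) for antiproliferative activity, read by MTT assay, with a stated time of 24 h (on this read-out lower numbers stand for stronger inhibition and higher numbers for weaker inhibition), compound 1 holds the lower of the two numbers, and the gap up to compound 2 lies well beyond the usual scatter. Among the measured compounds shown here, with only two values, the ranking can say no more than that.

Next comes compound 3 `COc1ccc(-c2noc(-c3ccc(Cl)cc3)n2)cc1OC1CCCC1` which keeps the core of compound 1 and exchanges one group, with 4-chlorophenyl in place of pyrrolidin-2-yl on an aromatic carbon. For the measured compounds named here, no measured pair isolates this change, so its size can only be judged indirectly. Compound 2 also lacks pyrrolidin-2-yl and carries a six-membered aromatic ring of carbon only at that place, and compound 2 gives 23700 nM in this assay as its result. It differs from compound 1 elsewhere too, so this is weak guidance. A rise beyond the scatter, towards weaker inhibition, is expected, estimated as a 35-fold higher number from compound 1 to compound 3 (1.54 log units; beyond the scatter) for this change. The estimated value for compound 3 is 1500 nM within an expected range of 150 nM to 15000 nM in this measurement.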

Compound 3, half-maximal inhibitory concentration: 20800 nM
Beside the measured number, compound 3's estimate is 14-fold (1.14 log units) below it; measured number outside the range, above it.
By their numbers in this assay, from the lowest: compound 1; then compounds 3 and 2 (each within the scatter of the next).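

In this assay, putting 4-chlorophenyl in place of pyrrolidin-2-yl on this aromatic carbon of the five-membered aromatic ring gives a 480-fold higher number from compound 1 to compound 3 (2.68 log units; beyond the scatter), a large step towards weaker inhibition. The rest of the molecule stays the same in this pair. Among the compounds shown here, it gives the first direct reading of this position, and the position is clearly sensitive to what sits there, at least for this one exchange. The exchange alters several things at once, as a five-membered non-aromatic ring with a hydrogen-bond donor and acceptor gives way to a six-membered aromatic ring of carbon only that has neither, and no measurement here shows which of these differences accounts for the step.

As far as these compounds go, with a single exchange at this place, it remains open whether the ring nitrogen of pyrrolidin-2-yl, the ring itself or the chlorine matters most. Groups such as aminomethyl, piperidin-2-yl or cyclopentyl at the same place could help separate these possibilities, showing whether an amine alone is enough to keep the number low or whether a non-aromatic ring also plays a part.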